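The source may report more compounds than this note shows. Statements on the series, on what has been measured and on what is new or still open speak of the compounds shown alone.

In a functional assay on RS4-11 cells (Homo sapiens) for inhibition, read by CCK-8 assay, with a stated time of 48 h (on this read-out lower numbers stand for stronger inhibition and higher numbers for weaker inhibition), compound 3 (`COc1ccc(NC(=O)NCCNS(=O)(=O)c2sccc2-c2ccc(C)cc2Oc2ccc(O)c(O)c2)cc1`) gives 8200 nM. Compound 1 (`O=S(=O)(NCCNC(=S)Nc1cc(C(F)(F)F)cc(C(F)(F)F)c1)c1ccc(-c2ccccc2OCc2cccc(O)c2)s1`) gives 12000 nM, and these two numbers lie within the usual scatter of each other, so the data do not separate them. Compound 2 (`COc1ccc(NC(=O)NCCNS(=O)(=O)c2ccc(-c3ccccc3OCc3ccccc3)s2)cc1`) returns only a limit of the assay, > 20000 nM, and not an exact number. Among the compounds with values here, compound 3 therefore shares the only range of actual numbers seen so far with compound 1, in the low micromolar-to-ten-thousands part of the scale.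

The next compound to consider is compound 4 (`Cc1ccc(-c2ccsc2S(=O)(=O)NCCNC(=O)Nc2cc(Cl)cc(Cl)c2)c(Oc2ccc(O)c(O)c2)c1`). It keeps everything in compound 3 except one group: 3,5-dichlorophenyl takes the place of 4-methoxyphenyl on an amide-type nitrogen whose other neighbour is the carbonyl carbon (3,5-dichlorophenyl in place of 4-methoxyphenyl on an amide-type nitrogen). The swap removes the single oxygen of the leaving group and brings in two chlorines, while the heavy-atom count stays the same.

Within the data shown here, no measured pair isolates a swap of this kind, so the expectation stays anchored on compound 3 at 8200 nM. The expected change is a 1.5-fold lower number from compound 3 to compound 4 (0.17 log units; within the scatter), an estimated step that leans toward stronger inhibition but stays within the scatter. For compound 4 the estimate is 5500 nM, with an expected range from 1800 nM to 16000 nM.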

Compound 4, half-maximal inhibitory concentration: 5100 nM
The estimate for compound 4 lay 1.1-fold (0.03 log units) above the measured number, within the range that was stated.
By their numbers in this assay, from the lowest: compounds 4, 3 and 1 (each within the scatter of the next, the first and the last beyond it). At a limit, above all of these: compound 2.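

Within the data shown here, this is the first pair of compounds that differ in only one place, the group on the amide-type nitrogen whose other neighbour is the carbonyl carbon, and in this assay it gives a 1.6-fold lower number from compound 3 to compound 4 (0.21 log units; within the scatter). On this nitrogen, then, 3,5-dichlorophenyl and 4-methoxyphenyl cannot be told apart by this read-out, even though the entering group carries chlorine and the leaving group carries oxygen. Nothing among the data shown explains this step.

Both groups are six-membered aromatic rings of carbon only, so the compounds shown leave open how a saturated ring such as cyclohexyl, or a nitrogen-containing ring such as pyridyl, would read on this nitrogen in this assay. On these data alone, it also remains open whether a phenyl ring bearing a carboxylic acid or an amine would give a number that lies beyond the scatter from those of compound 3 and compound 4.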